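Chain length on the core of compound 3 and what a longer chain may bring

The source may hold more compounds than are shown below. What is called first, only, known or untested is meant among the compounds shown, and "the series" means these compounds.

In a functional assay on HeLa cells (Homo sapiens) for inhibition, read by MTT assay, with a stated time of 72 h (on this read-out higher numbers stand for weaker inhibition and lower numbers for stronger inhibition), compound 1 `Nc1nc2cc(-c3nn(CCCCCC(=O)NO)c4ncnc(N)c34)ccc2o1` gives 15400 nM. Compound 2 `Nc1nc2cc(-c3nn(CCCC(=O)NO)c4ncnc(N)c34)ccc2o1` reaches only a limit of the assay, > 150000 nM. Compound 3 `Nc1nc2cc(-c3nn(CCC(=O)NO)c4ncnc(N)c34)ccc2o1` likewise stands at a limit, > 150000 nM, and so the numbers shown place it at the weak end of the set without a number of its own. Two of the three values meet at the same boundary: the limit of > 150000 nM in this assay, at which 2 of the 3 values shown sit.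

Compound 4 `Nc1nc2cc(-c3nn(CCCCCCCCC(=O)NO)c4ncnc(N)c34)ccc2o1` differs from compound 3 by 6-(hydroxycarbamoyl)hexyl in place of hydroxycarbamoyl on a saturated chain carbon, two bonds along the chain from an aromatic nitrogen. Going by the values given here, the steps that bear on this change are those of chain length. Shortening the chain gave an at least 9.7-fold higher number from compound 1 to compound 3 (0.98 log units; beyond the scatter) and, in the same sense, an at least 9.7-fold higher number from compound 1 to compound 2 (0.98 log units; beyond the scatter); between the two limits the step that the two limits leave unreadable from compound 2 to compound 3. Compound 4 carries a chain longer than that of compound 1, so the step is expected to run the other way, towards a lower number, and at least as far as the shortening did: an at least 25-fold lower number from compound 3 to compound 4 (1.39 log units; beyond the scatter). Compound 4 is therefore expected to give 6000 nM, with a range from 1200 nM to 30000 nM, the upper end allowing for the possibility that the extension beyond compound 1 brings no further gain.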

Compound 4, half-maximal inhibitory concentration: 10200 nM
Estimate against measurement, compound 4: 1.7-fold (0.23 log units) below, and the stated range covers the measured number.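

In this assay, the chain of compound 4, with 6-(hydroxycarbamoyl)hexyl in place of hydroxycarbamoyl, turns a core that had stood at a limit into one with a measured number: an at least 14-fold lower number from compound 3 to compound 4 (1.16 log units; beyond the scatter), and likewise an at least 14-fold lower number from compound 2 to compound 4 (1.16 log units; beyond the scatter). Neither step has a fixed size, since each starts from a limit and not from a number: the limit of > 150000 nM in this assay, at which 2 of the 4 values shown sit. The new point lies in the comparison with compound 1, a 1.5-fold lower number from compound 1 to compound 4 (0.18 log units; within the scatter), which leaves the two compounds level within the scatter, so that in these four compounds the longer chain of compound 4 adds no readable gain over the chain of compound 1, and a longer chain does not simply mean a lower number once that length is reached.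

What the compounds shown leave open is how the numbers run at chain lengths other than these four, including a still longer chain than that of compound 4. They also leave open whether the hydroxycarbamoyl end itself matters, since every compound carries it and none has a carboxylic acid or a primary amide at the end of the same chain.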